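From 4-hydroxycyclohexyl to 3,4-dihydroxyphenyl on the shared core

A few compounds are considered here, and "the series" means these few. Any claim that something is new, unique, unknown or untested is made for them only; others in the source may bear on it.

Measured in a functional assay on RS4-11 cells (Homo sapiens) for inhibition, read by CCK-8 assay, with a stated time of 48 h; a higher number here means a weaker inhibitor, a lower number a stronger inhibitor:
- Compound 1 `O=C(NCCNS(=O)(=O)c1ccc(-c2ccccc2OCc2cccc(O)c2)s1)Nc1cc(C(F)(F)F)cc(C(F)(F)F)c1` gives 3000 nM
- Compound 2 `O=C(NCCNS(=O)(=O)c1ccc(-c2ccccc2O[C@H]2CC[C@@H](O)CC2)s1)Nc1cc(C(F)(F)F)cc(C(F)(F)F)c1` gives 9300 nM
- Compound 3 `O=[N+]([O-])c1ccc(Oc2ccccc2-c2ccc(S(=O)(=O)NCCNC(=S)Nc3cccc(Cl)c3)s2)cc1` gives > 50000 nM, a limit of the assay and not a number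

Among the compounds with values here, of the two numbers available, compound 2 stands higher at 9300 nM, and the only value it can be set against is that of compound 1 at 3000 nM. Within the data shown here, compound 3 offers only its limit and no measured step.

The next compound is compound 4 `O=C(NCCNS(=O)(=O)c1ccc(-c2ccccc2Oc2ccc(O)c(O)c2)s1)Nc1cc(C(F)(F)F)cc(C(F)(F)F)c1`, which carries 3,4-dihydroxyphenyl in place of 4-hydroxycyclohexyl on an oxygen on an aromatic ring.

Among the measured compounds shown here, one measured step bears on this change: a 3.1-fold higher number from compound 1 to compound 2 (0.49 log units; beyond the scatter). In that step, 4-hydroxycyclohexyl took the place of 3-hydroxybenzyl and the number rose. Compound 4 again has an aromatic ring in this region, as compound 1 does, but 3,4-dihydroxyphenyl is a different group from 3-hydroxybenzyl, so this single step is only a loose guide.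

In this assay a modest move to a lower number is therefore expected, roughly undoing that rise. The expected change is a 2.7-fold lower number from compound 2 to compound 4 (0.42 log units; beyond the scatter). The estimate for compound 4 is 3500 nM, with an expected range of 1200 nM to 11000 nM.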

Compound 4, half-maximal inhibitory concentration: 4900 nM
For compound 4 the middle estimate is 1.4-fold (0.15 log units) below the measured one; the measured number falls inside the stated range.
By their numbers in this assay, from the lowest: compounds 1, 4 and 2 (each within the scatter of the next, the first and the last beyond it). At a limit, above all of these: compound 3.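

In this assay the change from 4-hydroxycyclohexyl to 3,4-dihydroxyphenyl gives a 1.9-fold lower number from compound 2 to compound 4 (0.28 log units; within the scatter) and the change from 3-hydroxybenzyl to 3,4-dihydroxyphenyl gives a 1.6-fold higher number from compound 1 to compound 4 (0.21 log units; within the scatter) and so compound 4 cannot be told apart from either of the other two. Taken alone, the earlier pair, with a 3.1-fold higher number from compound 1 to compound 2 (0.49 log units; beyond the scatter) as its step, could be read as a cost of putting a non-aromatic ring on this oxygen; with compound 4 within the scatter of both, that reading no longer holds on the aromatic ring alone. Nothing measured here accounts for these numbers.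

The compounds shown leave open what a plain phenoxy group, or a phenoxy group carrying an amine or a carboxylic acid, would do on this oxygen. Compound 3 gives > 50000 nM as a limit of the assay and not a number, and it differs from the others in more than one place, so that limit cannot be tied to any single change.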